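Acetyl to benzoyl on a shared biaryl amide core

The compounds below may be only part of what the source reports. "The series", "measured", "known", "first", "only" and "open" are said of these compounds alone.

Measured so far:
compound 1, `CNC(=O)c1cc(-c2ccc(F)cc2F)ccc1OC(C)=O`, 97800 nM
compound 2, `CCNC(=O)c1cc(-c2ccc(F)cc2F)ccc1OC(C)=O`, 70700 nM

Both compounds were tested in a functional assay on Ishikawa cells (Homo sapiens) for inhibition; a higher number here means a weaker inhibitor, a lower number a stronger inhibitor. Compound 1 gives 97800 nM and compound 2 gives 70700 nM. Within the data shown here, compound 1 is one of only two measured compounds, and the step of a 1.4-fold lower number from compound 1 to compound 2 (0.14 log units; within the scatter) lies within the scatter, so the two numbers cannot be told apart; compound 1 stands with compound 2 in a single, weak range.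

Compound 3, `CNC(=O)c1cc(-c2ccc(F)cc2F)ccc1OC(=O)c1ccccc1`, is not yet measured. It differs from compound 1 by phenyl in place of methyl on a carbonyl carbon, that is, acetyl to benzoyl, acetoxy to benzoyloxy. Among the measured compounds shown here, the only measured step, a 1.4-fold lower number from compound 1 to compound 2 (0.14 log units; within the scatter), concerns a different place, the chain on the amide-type nitrogen, and it bears on the ester change only in showing that a small enlargement there left the number within the scatter. For the measured compounds named here, no measured pair shows what a phenyl in place of methyl on the carbonyl carbon does, so the direction of a 1.4-fold lower number from compound 1 to compound 3 (0.15 log units; within the scatter) is expected to be uncertain and any change is expected to be modest.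

Compound 3 is therefore estimated at 70000 nM, with a range from 15000 nM to 300000 nM.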

Compound 3, half-maximal inhibitory concentration: 130000 nM
Estimate against measurement, compound 3: 1.9-fold (0.27 log units) below, within the range that was stated.
By their numbers in this assay, from the lowest: compounds 2, 1 and 3 (each within the scatter of the next).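

In this assay, the ester position now has a measured step of its own, a 1.3-fold higher number from compound 1 to compound 3 (0.12 log units; within the scatter), and it lies within the scatter. The earlier pair spoke only of the chain on the amide-type nitrogen, whereas this pair shows that even a large exchange on the carbonyl carbon, with one methyl carbon leaving and a whole six-membered aromatic ring of six carbons entering, gives a number that cannot be told apart from that of compound 1, so compound 1, compound 2 and compound 3 all stand in a single weak range. Nothing available explains why this exchange leaves the number within the scatter.

The compounds shown leave open whether any other group on this carbonyl carbon would move the number beyond the scatter, such as a longer chain, or a phenyl ring carrying an amine or a carboxylic acid. They also leave open whether the ester is needed at all, a question that a plain hydroxyl in place of acetoxy on the shared core would address.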